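The source may report more compounds than this note shows. Statements on the series, on what has been measured and on what is new or still open speak of the compounds shown alone.

Compound 3 `CCCN(CCC)c1ccc2cc(NC(=O)CCc3ccc(C(F)(F)F)cc3)ccc2n1` stands highest of the three compounds measured in an assay on isolated protein for displacement of a labelled ligand from melanin-concentrating hormone receptor 1 (Homo sapiens); on this read-out lower numbers stand for stronger inhibition and higher numbers for weaker inhibition: compound 3 gives 490 nM, whereas compound 1 `CN(c1ccc2cc(NC(=O)CCc3ccc(C(F)(F)F)cc3)ccc2n1)C1CCCCC1` gives 18 nM and compound 2 `CC1CCCN1c1ccc2cc(NC(=O)CCc3ccc(C(F)(F)F)cc3)ccc2n1` gives 5 nM. Compound 4 `O=C(CCc1ccc(C(F)(F)F)cc1)Nc1ccc2nc(N3CCC(c4ccccc4)C3)ccc2c1` differs from compound 3 by 3-phenylpyrrolidin-1-yl in place of dipropylamino on an aromatic carbon. Two measured steps bear on this exchange: a 98-fold higher number from compound 2 to compound 3 (1.99 log units; beyond the scatter) and a 27-fold higher number from compound 1 to compound 3 (1.43 log units; beyond the scatter), both large, both showing that the dipropylamino compound gives by far the highest number among these three. Restoring a ring amine, here 3-phenylpyrrolidin-1-yl, is therefore expected to bring a large step downward in this assay, a 33-fold lower number from compound 3 to compound 4 (1.51 log units; beyond the scatter). Compound 4 is expected to land near 15 nM, most probably between 3 nM and 80 nM.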

Compound 4, half-maximal inhibitory concentration: 25 nM
Beside the measured number, compound 4's estimate is 1.7-fold (0.22 log units) below it, and the stated range covers the measured number.
By their numbers in this assay, from the lowest: compound 2; then compounds 1 and 4 (each within the scatter of the next); then compound 3.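

In this assay, the 3-phenylpyrrolidin-1-yl ring on the aromatic carbon next to the ring nitrogen shows that this position accepts a ring amine carrying a phenyl group, with a large gain over dipropylamino (a 20-fold lower number from compound 3 to compound 4 (1.29 log units; beyond the scatter)). That phenyl-bearing ring does not match the 2-methylpyrrolidin-1-yl ring (a 5.0-fold higher number from compound 2 to compound 4 (0.70 log units; beyond the scatter)), and it cannot be told apart from cyclohexyl(methyl)amino (a 1.4-fold higher number from compound 1 to compound 4 (0.14 log units; within the scatter)). No measurement offered here accounts for these differences.

Still open, from the compounds shown here alone, is how an unsubstituted pyrrolidin-1-yl or a piperidin-1-yl ring would read here, and whether a phenyl group on the 2-carbon of the pyrrolidine would differ from one on the 3-carbon.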